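The source may report more compounds than this note shows. Statements on the series, on what has been measured and on what is new or still open speak of the compounds shown alone.

Measured so far:
compound 1, `CCCCCCCC#CC#C/C=C\C(C)=O`, gives > 50 ug/mL
compound 2, `CCCCCCCC#CC#CC1CC(=O)C=C(C)C1`, gives 45.1 ug/mL

Of the compounds shown here, two have been tested in a functional assay on HCT-15 cells (Homo sapiens) for cytotoxicity; a higher number here means that more compound is needed for the effect, a lower number that less compound is needed. For compound 1 the result is a limit of the assay, > 50 ug/mL, not a number. Compound 2 gives a numerical value of 45.1 ug/mL in this assay. Because only the limit of > 50 ug/mL in this assay, at which 1 of the 2 values shown sits, is known for compound 1, its exact position on the scale is open; it stands at the limit, and that is all that can be said about it.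

The next compound, compound 3, `CCCCCCCC#CC#C/C=C/C(C)=O`, has not yet been measured. It is related to compound 1 by a single change: the two compounds have the same atoms and bonds and differ only in configuration as drawn: 1 of 1 stereo elements differ; a double bond is drawn Z in compound 1 and E in compound 3. Within the data shown here, no measured pair of compounds shares exactly this kind of change, so there is no step from which its size can be read.

The expectation for compound 3 is therefore tentative. Compound 3 is expected to give about 35 ug/mL in this assay, with a likely range from 10 ug/mL to 100 ug/mL. That estimate means a step of an at least 1.4-fold lower number from compound 1 to compound 3 (0.15 log units; that floor lies within the scatter), which may well be no change at all beyond the scatter, and the result for compound 3 could again come back as a limit.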

Compound 3, concentration for half-maximal effect: 3.7 ug/mL
The estimate for compound 3 lay 9.5-fold (0.98 log units) above the measured number; the measured number lies below the stated range.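

The geometry of a single double bond matters strongly in this assay: going from Z to E as drawn amounts to an at least 13-fold lower number from compound 1 to compound 3 (1.13 log units; beyond the scatter). Among these compounds, with no atom added or removed, this step can be tied to that double bond alone, which the two earlier compounds could not show, since no measured pair yet isolated one change: the fact that compounds 1 and 3 differ only in the configuration as drawn. On these data alone, the result for compound 1 is a limit of the assay, so the step is a floor and its full size remains unknown: the limit of > 50 ug/mL in this assay, at which 1 of the 3 values shown sits.

The compounds shown do not reveal whether the E double bond would bring a step of similar size with a longer chain, or with an amide or a carboxylic acid in place of the carbonyl group. As far as these compounds go, they also do not explain why the configuration has such an effect, and they speak only to this one cell-based assay, so whether the same preference holds in other cells remains open.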